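Swapping a bromophenyl sulfide for a bromophenyl sulfone

The source may report more compounds than this note shows. Statements on the series, on what has been measured and on what is new or still open speak of the compounds shown alone.

Measured compounds:
- compound 1, `CCCCN(O)C(=O)Nc1cc([C@@H]2CC[C@@H](c3cc(OC)c(OC)c(OC)c3)O2)cc(OC)c1OCCSc1ccc(Br)cc1`, gives 21 nM in an assay for displacement of a labelled ligand from platelet-activating factor receptor (Homo sapiens); a higher number here means a weaker inhibitor, a lower number a stronger inhibitor
- compound 2, `CCCCN(O)C(=O)Nc1cc([C@@H]2CC[C@@H](c3cc(OC)c(OC)c(OC)c3)O2)cc(OC)c1OCCS(=O)(=O)c1c(F)c(F)cc(F)c1F`, gives 285 nM in this assay

Of the two numbers in hand, compound 1 holds the lower one; compound 2 sits well above it, by a gap beyond the usual scatter. Compound 3, `CCCCN(O)C(=O)Nc1cc([C@@H]2CC[C@@H](c3cc(OC)c(OC)c(OC)c3)O2)cc(OC)c1OCCS(=O)(=O)c1ccccc1Br`, has not yet been measured in this assay. It departs from compound 1 in one place: (2-bromophenyl)sulfonyl in place of (4-bromophenyl)sulfanyl on a saturated chain carbon, two bonds along the chain from an oxygen on an aromatic ring. For the measured compounds named here, no step between measured compounds matches this change, but compound 2, which also carries a sulfonyl on that chain, gives 285 nM, a weaker result than compound 1. On that basis the step from compound 1 to compound 3 is expected to weaken binding, a 3.8-fold higher number from compound 1 to compound 3 (0.58 log units; beyond the scatter), though by less than the gap to compound 2. Compound 3 is therefore estimated at 80 nM, with a plausible range from 20 nM to 320 nM.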

Compound 3, half-maximal inhibitory concentration: 25 nM
Beside the measured number, compound 3's estimate is 3.2-fold (0.51 log units) above it; low and high end bracket the measured number.
By their numbers in this assay, from the lowest: compounds 1 and 3 (each within the scatter of the next); then compound 2.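

In this assay, (2-bromophenyl)sulfonyl in place of (4-bromophenyl)sulfanyl gives a 1.2-fold higher number from compound 1 to compound 3 (0.08 log units; within the scatter), so a sulfonyl on this chain does not by itself go with the weaker number of compound 2. With the sulfonyl kept, 2-bromophenyl in place of 2,3,5,6-tetrafluorophenyl on the sulfonyl sulfur gives an 11-fold lower number from compound 2 to compound 3 (1.06 log units; beyond the scatter), which ties that gap to the aromatic group on the sulfur. Nothing measured here explains either step.

On these data alone, the step to compound 3 changes the sulfur and the place of the bromine together, so what each contributes alone stays open, as a 4-bromophenyl on a sulfonyl or a 2-bromophenyl on a sulfanyl would show. Also open, as far as these compounds go, is how a plain phenyl or a methyl on the sulfonyl sulfur, or a propyl chain in place of the ethyl, would fare.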